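The source may hold more compounds than are shown below. What is called first, only, known or untested is meant among the compounds shown, and "the series" means these compounds.

Compound 1, `CC(C)CN(c1ccc(N(C)C)cc1)S(=O)(=O)c1ccc2c(c1)C(O)CC(C1CCOCC1)O2`, gives 3.51 in a physicochemical assay for lipophilicity, at pH 7.4; a higher number here means a more lipophilic compound, a lower number a more polar compound. That is the lowest of the three measured numbers. Compound 3, `CCc1ccc(N(CC(C)C)S(=O)(=O)c2ccc3c(c2)C(O)C[C@H](C2CCOCC2)O3)cc1`, gives 4.12 in this assay, a number higher than that of compound 1 by more than the usual scatter, and compound 2, `CCc1ccc(N(CC(C)C)S(=O)(=O)c2ccc3c(c2)CCC3OC2CCOCC2)cc1`, gives 4.96, higher still and furthest from compound 1.

Compound 4, `CC(C)CN(c1cccc(F)c1)S(=O)(=O)c1ccc2c(c1)C(O)CC(C1CCOCC1)O2`, has not yet been measured. It differs from compound 1 in one place: 3-fluorophenyl in place of 4-(dimethylamino)phenyl on a sulfonamide nitrogen. The group that leaves carries one hydrogen-bond acceptor and two more heavy atoms than the group that enters, which carries none.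

Going by the values given here, no pair of measured compounds differing in one place is available, so the expected size of the step must rest on the structures alone. The swap removes an acceptor while shrinking the group slightly, and these two features pull in opposite directions. The expected step in this assay is therefore small, a number 0.19 log units higher from compound 1 to compound 4 (within the scatter), likely within or only a little beyond the scatter, and if anything toward the more lipophilic side. Compound 4 is accordingly estimated at 3.7 in this assay, in a range from 3.2 to 4.3.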

Compound 4, distribution coefficient: 3.39
Beside the measured number, compound 4's estimate is 0.31 log units above it; low and high end bracket the measured number.
By their numbers in this assay, from the lowest: compounds 4 and 1 (each within the scatter of the next); then compound 3; then compound 2.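

Going by these compounds alone, compound 1 and compound 4 give the first comparison in which a single group on the sulfonamide nitrogen changes while the rest of the structure stays fixed: in this assay, putting 3-fluorophenyl in place of 4-(dimethylamino)phenyl gives a number 0.12 log units lower from compound 1 to compound 4 (within the scatter). Within the data shown here, at this place, then, exchanging a group that carries a hydrogen-bond acceptor for a smaller one that carries none produces no change that can be told from the scatter of this assay, and compound 1 and compound 4 read as equal here, something the earlier compounds, none of them a one-place pair, could not show. Nothing measured in the material shown explains this outcome.

A single pair cannot say whether the same holds for other groups at this place, such as a phenyl ring carrying a carboxylic acid or a primary amine, a pyridine ring, or a saturated ring such as morpholine. Among these compounds, it also leaves open whether this exchange would give a comparable step on a compound with a different core or a different chain on the sulfonamide nitrogen, for instance a longer chain in place of the one shared by compound 1 and compound 4.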